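The source may hold more compounds than are shown below. What is called first, only, known or untested is meant among the compounds shown, and "the series" means these compounds.

Working notes on the ester series, read-out a physicochemical assay for lipophilicity; on this read-out higher numbers stand for higher lipophilicity and lower numbers for lower lipophilicity.

Compound 1 `C=CCOC(=O)/C=C(C)/C=C/CC(C)CCCC(C)C` is the parent of the first pair; in this assay compound 1 gives 6.73. Compound 2 `C=CCOC(=O)/C=C(C)/C=C/CC(C)CCCC(C)(C)OC` carries the change methoxy in place of hydrogen on a saturated chain carbon bound to three saturated chain carbons and in this assay compound 2 gives 5.53. The step of a number 1.20 log units lower from compound 1 to compound 2 (beyond the scatter) is the only measured effect of this change so far.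

Compound 3 `COC(CCC(C)C/C=C/C(C)=C/C(=O)OC(C)C)C(C)C` has a different core; the difference between the core of compound 1 and the core of compound 3 is not broken down here. In this assay compound 3 gives 5.95, which places it between the two compounds of the first pair, lower than compound 1 and higher than compound 2, each gap beyond the scatter.

Compound 4 `COC(CCC(C)C/C=C/C(C)=C/C(=O)OC(C)C)C(C)(C)OC`, not yet measured, is made from compound 3 by methoxy in place of hydrogen on a saturated chain carbon bound to three saturated chain carbons. The place is the same in words as for the first pair, so this is the same change, now on the core of compound 3, where the reading one bond further out is 1-methoxy-2-methylpropyl to 1,2-dimethoxy-2-methylpropyl rather than isobutyl to 2-methoxy-2-methylpropyl. Within the data shown here, with a single precedent, the step from compound 3 to compound 4 is expected to be a number 1.10 log units lower from compound 3 to compound 4 (beyond the scatter), close to the earlier one, because a number 1.20 log units lower from compound 1 to compound 2 (beyond the scatter) is the only guide, and the second methoxy on the same branch of compound 3 may make the fall somewhat smaller. Compound 4 is therefore estimated at 4.85 in this assay, with the range 4.35 to 5.35 expected to hold the result.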

Compound 4, partition coefficient: 4.75
The estimate for compound 4 lay 0.10 log units above the measured number; low and high end bracket the measured number.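

In this assay, methoxy in place of hydrogen on a saturated chain carbon bound to three saturated chain carbons gives a number 1.20 log units lower from compound 3 to compound 4 (beyond the scatter) on the core of compound 3, a step of the same printed size as a number 1.20 log units lower from compound 1 to compound 2 (beyond the scatter) on the core of compound 1, so in these two pairs the change carries from one core to the other with no difference in size, also where the group changed is 1-methoxy-2-methylpropyl rather than isobutyl. Two pairs do not make a general rule for the series, and they show nothing about this change on any other core or at any other place on the chain. Nothing available here bears on why the two steps match.

The compounds shown leave open whether the step would keep its size with a different entering group, such as ethoxy or hydroxy, in place of methoxy. They also leave open whether it would hold on a core that carries an amine or a carboxylic acid, or on one with a longer chain.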